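Three weak triazole amides and an untested aryl analogue

The source may hold more compounds than are shown below. What is called first, only, known or untested is meant among the compounds shown, and "the series" means these compounds.

Compound 1 `Nc1nccc2cc(CNC(=O)Cn3cnc(C(=O)NC4CCCCC4)n3)ccc12`: > 100000 nM
Compound 2 `O=C(Cn1cnc(C(=O)NC2CCCCC2)n1)NCc1ccc2[nH]ncc2c1`: > 100000 nM
Compound 3 `Cc1ccc(NC(=O)c2ncn(CC(=O)NCCn3cnc4[nH]ccc4c3=O)n2)cc1C`: 138000 nM

The three measured compounds share a triazole carboxamide core and were tested in an assay for inhibition of histone-lysine N-methyltransferase, H3 lysine-79 specific (Homo sapiens), read by luminescence, with a stated time of 1 h; on this read-out higher numbers stand for weaker inhibition and lower numbers for stronger inhibition. Compound 1 `Nc1nccc2cc(CNC(=O)Cn3cnc(C(=O)NC4CCCCC4)n3)ccc12` reached only a limit of the assay, > 100000 nM, and not a number. Compound 2 `O=C(Cn1cnc(C(=O)NC2CCCCC2)n1)NCc1ccc2[nH]ncc2c1` likewise gave only a limit, > 100000 nM. Compound 3 `Cc1ccc(NC(=O)c2ncn(CC(=O)NCCn3cnc4[nH]ccc4c3=O)n2)cc1C`, which carries the 3,4-dimethylphenyl amide on a different tail, gave a number in this assay, 138000 nM, a very weak result. Compound 2 therefore stands at the limit of > 100000 nM in this assay, at which 2 of the 3 values shown sit, among the weakest positions the data can show.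

Compound 4 `Cc1ccc(NC(=O)c2ncn(CC(=O)NCc3ccc4[nH]ncc4c3)n2)cc1C` differs from compound 2 in one place: 3,4-dimethylphenyl in place of cyclohexyl on an amide-type nitrogen. In words, 3,4-dimethylphenyl replaces cyclohexyl on an amide-type nitrogen. For the measured compounds named here, no step between measured compounds isolates this change, so its size is unknown. Compound 3 shows that the 3,4-dimethylphenyl amide, on another tail, gives only a very weak result, 138000 nM, so no gain beyond the scatter is expected in this assay. Compound 4 is expected to remain very weak, with an estimated step that the limit leaves unreadable from compound 2 to compound 4 and an estimated value of 150000 nM, in the range 50000 nM to 500000 nM, quite possibly reported only as a limit.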

Compound 4, half-maximal inhibitory concentration: 36900 nM
The estimate for compound 4 lay 4.1-fold (0.61 log units) above the measured number; measured number below the stated range.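

For the compounds shown here, with the tail of compound 2 held fixed, 3,4-dimethylphenyl in place of cyclohexyl on an amide-type nitrogen gives the first readable change in this assay, an at least 2.7-fold lower number from compound 2 to compound 4 (0.43 log units; beyond the scatter), so this position does affect the read-out. The step has only one bound, and compound 2 gives a limit of the assay and not a number: the limit of > 100000 nM in this assay, at which 2 of the 4 values shown sit. The aryl amide does not set the number by itself, as the same 3,4-dimethylphenyl amide on a different tail stands at 138000 nM in compound 3, while in compound 4 it reaches 36900 nM, still a weak result in absolute terms.

The compounds shown leave open how large the step really is, and whether it follows from the aromatic ring or from its two methyl groups, a question that an unsubstituted phenyl on the same nitrogen would address. They also leave open how other groups at this position would read, such as a benzyl or a 4-methoxyphenyl, and whether any of them would carry the series further on this tail.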